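A few compounds are considered here, and "the series" means these few. Any claim that something is new, unique, unknown or untested is made for them only; others in the source may bear on it.

Measured in a functional assay on L1210 cells (Mus musculus), with a stated time of 48 h; a lower number here means a stronger inhibitor, a higher number a weaker inhibitor:
- compound 1 `CCOC(=O)Nc1cc(NC(C)C(=O)Cc2ccccc2)c([N+](=O)[O-])c(N)n1`: 10000 nM
- compound 2 `CCCCC(=O)C(C)Nc1cc(NC(=O)OCC)nc(N)c1[N+](=O)[O-]`: 54000 nM
- compound 3 `CCCCC(O)C(C)Nc1cc(NC(=O)OCC)nc(N)c1[N+](=O)[O-]`: 55000 nM

Compound 3, at 55000 nM, sits at the weak end of this small set, a place it shares. The nearest measurement is a 1.0-fold higher number from compound 2 to compound 3 (0.01 log units; within the scatter), which is no real difference. The furthest is a 5.5-fold higher number from compound 1 to compound 3 (0.74 log units; beyond the scatter).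

Compound 4 `CCCCC(O)C(C)Nc1cc(NC(=O)OCC)nc(N)c1N` has not been measured yet. It differs from compound 3 in one place: amino in place of nitro on an aromatic carbon. In words, this is amino in place of nitro on an aromatic carbon, para to a (ethoxycarbonyl)amino group.

Going by the values given here, all three measured compounds carry the nitro group, so no measured step shows what this swap does. Among the compounds with values here, the only guide is how far the numbers have moved for changes elsewhere on the molecule. Those moves were modest, as in a 5.4-fold higher number from compound 1 to compound 2 (0.73 log units; beyond the scatter), or absent, as in the step between compounds 2 and 3 already given. This swap touches a different part of the molecule, so the expectation is loose. A modest move toward a lower number seems likeliest, but a move the other way cannot be ruled out. The expected change is a 2.8-fold lower number from compound 3 to compound 4 (0.44 log units; beyond the scatter). The estimate for compound 4 is 20000 nM, with an expected range from 4000 nM to 80000 nM.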

Compound 4, half-maximal inhibitory concentration: 18000 nM
For compound 4 the middle estimate is 1.1-fold (0.05 log units) above the measured one; low and high end bracket the measured number.
By their numbers in this assay, from the lowest: compounds 1 and 4 (each within the scatter of the next); then compounds 2 and 3 (each within the scatter of the next).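

In this assay, replacing nitro with amino on this aromatic carbon, para to a (ethoxycarbonyl)amino group, gives a 3.1-fold lower number from compound 3 to compound 4 (0.49 log units; beyond the scatter). Going by these compounds alone, the earlier steps changed only the side chain, so this is the first sign that the number also responds to a change on the ring itself, and the swap exchanges a group of 3 heavy atoms and 0 hydrogen-bond donors for one of 1 heavy atom and 1 hydrogen-bond donor. The nitro group is thus not required for the inhibition seen here, since compound 4 lacks it and gives 18000 nM, but no measurement available here explains why the number moves in this direction.

Going by these compounds, only nitro and amino have been compared at this position, so it remains unknown whether a methylamino, acetylamino or dimethylamino group there would lower the number further or raise it again. The swap is also shown on the 1-hydroxypentyl side chain alone, which leaves open whether amino in place of nitro would have a similar effect with the butylcarbonyl or benzylcarbonyl groups.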